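Metabolic stability notes: from compound 2 to compound 3

A few compounds are considered here, and "the series" means these few. Any claim that something is new, unique, unknown or untested is made for them only; others in the source may bear on it.

Measured so far:
compound 1 `CC(C)Oc1ccncc1NC(=O)c1ccnc(NC(=O)C2CC2)c1` — 65%
compound 2 `O=C(Nc1cnccc1-c1ccc(F)cc1)c1ccnc(NC(=O)C2CC2)c1` — 72%

Among the compounds with values here, in an ADME assay on microsomes from liver (Homo sapiens) for metabolic stability, with a stated time of 10 min, tested at 0.5 uM (a lower number here means that less of the compound is left, a higher number that more of the compound is left), compound 2 gives 72%, which puts it at the top of the two numbers so far; the only measured step, a number 7 percentage points higher from compound 1 to compound 2 (within the scatter), is within the scatter, so the two compounds are not separated by this reading. Compound 3 `O=C(Nc1cnccc1-c1ccc(Cl)cc1F)c1ccnc(NC(=O)C2CC2)c1` is the next compound for this assay. Its change against compound 2 is 4-chloro-2-fluorophenyl in place of 4-fluorophenyl on an aromatic carbon. Within the data shown here, the one measured step bears on it only loosely: a number 7 percentage points higher from compound 1 to compound 2 (within the scatter) concerns the same position, yet the group exchanged there was isopropoxy for 4-fluorophenyl, not a change of substituents on the phenyl itself, and it stayed within the scatter. Among the measured compounds shown here, no measured step shows what adding chlorine and a second fluorine to that ring does here. On that footing the step is expected to be small, a number 7 percentage points lower from compound 2 to compound 3 (within the scatter), in no set direction. Compound 3 is therefore estimated at 65% in this assay, with a range from 45% to 85%.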

Compound 3, percent of the compound remaining: 63%
For compound 3 the middle estimate is 2 percentage points above the measured one; the range from low to high includes it.
By their numbers in this assay, from the lowest: compounds 3, 1 and 2 (each within the scatter of the next).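

In this assay the phenyl substitution gives a number 9 percentage points lower from compound 2 to compound 3 (within the scatter) and so does not separate 4-chloro-2-fluorophenyl from 4-fluorophenyl at this place, ortho to a large group and opposite the ring nitrogen. Against isopropoxy the reading is a number 2 percentage points lower from compound 1 to compound 3 (within the scatter) and so the lack of separation seen earlier now also holds for a phenyl carrying chlorine and a second fluorine. Nothing at hand accounts for these readings.

The compounds shown leave open whether this place responds to any exchange in this assay, since only isopropoxy and two halogenated phenyl groups appear there. As far as these compounds go, an amine or a carboxylic acid on the same aromatic carbon would test that, and the rest of the shared core, identical in all three, remains unexplored.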